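The source may hold more compounds than are shown below. What is called first, only, known or untested is meant among the compounds shown, and "the series" means these compounds.

Compound 2 `O=C(Cc1cccnc1)c1cc2cc(O)ccc2[nH]1` stands with the lower of the two numbers recorded in an assay on isolated protein for inhibition of Indoleamine 2,3-dioxygenase 1 (Homo sapiens), read by spectrophotometry (on this read-out higher numbers stand for weaker inhibition and lower numbers for stronger inhibition), giving 37000 nM, while compound 1 `O=C(Cc1cccnc1)c1cc2cc(-c3ccccc3)ccc2[nH]1` gives 96000 nM. Going by the values given here, the one measured step, a 2.6-fold lower number from compound 1 to compound 2 (0.41 log units; beyond the scatter), replaced phenyl with hydroxy. Compound 3 `O=C(Cc1cccnc1)c1cc2cc(Cl)ccc2[nH]1` carries the change (chloro in place of hydroxy on an aromatic carbon), so the hydroxy that compound 2 gained over compound 1 is itself exchanged. Among the compounds with values here, no measured step covers chloro, and only the modest size of the phenyl-to-hydroxy step bears on it. The expected step, a 1.4-fold higher number from compound 2 to compound 3 (0.13 log units; within the scatter), is therefore small, likely within this assay's scatter. Compound 3 is estimated at 50000 nM, within 15000 nM to 160000 nM.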

Compound 3, half-maximal inhibitory concentration: 24600 nM
Beside the measured number, compound 3's estimate is 2.0-fold (0.31 log units) above it; low and high end bracket the measured number.
By their numbers in this assay, from the lowest: compounds 3 and 2 (each within the scatter of the next); then compound 1.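

Exchanging hydroxy for chloro at this position gives a 1.5-fold lower number from compound 2 to compound 3 (0.18 log units; within the scatter) and so removes the hydrogen-bond donor and acceptor counted on hydroxy without a change beyond the scatter. Chloro in place of phenyl gives a 3.9-fold lower number from compound 1 to compound 3 (0.59 log units; beyond the scatter) and shows that a second single-atom group, not hydroxy alone, stands apart from phenyl here. No measurement at hand accounts for this result. As far as these compounds go, whether an amine, a carboxylic acid or a methoxy group at this position would move the number further remains open.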